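The compounds below may be only part of what the source reports. "The series", "measured", "known", "first", "only" and "open" are said of these compounds alone.

Of the compounds shown here, two with a shared core have already been measured in an assay on HEK293 cells for displacement of a labelled ligand from NPC1-like intracellular cholesterol transporter 1 (Homo sapiens); a lower number here means a stronger inhibitor, a higher number a weaker inhibitor. Compound 1 `O=C(CN1CN(c2ccccc2)C2(CCN(C(=O)c3ccc(C4CCCCC4)cc3)CC2)C1=O)N1CCC(CO)CC1` gives 1100 nM. Compound 2 `O=C(CN1CN(c2ccccc2)C2(CCN(C(=O)c3ccc(C4CCCCC4)cc3)CC2)C1=O)N1CCCCC1`, which carries a hydrogen in place of the hydroxymethyl group on a saturated ring carbon, gives 1100 nM. The step of no change at the digits printed from compound 1 to compound 2 (within the scatter) shows that removing the hydroxymethyl group left the binding unchanged, so compound 2 stands level with compound 1 in this assay.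

Compound 3 `CC1(C)CC(OC(=O)CN2CN(c3ccccc3)C3(CCN(C(=O)c4ccc(C5CCCCC5)cc4)CC3)C2=O)CC(C)(C)N1` changes the same end of the molecule once more: (2,2,6,6-tetramethylpiperidin-4-yl)oxy in place of piperidin-1-yl on a carbonyl carbon. Going by the values given here, the only measured step that touches this end is the one from compound 1 to compound 2, and it was flat, which suggests the terminal group tolerates variation, although replacing the ring nitrogen attachment by an oxygen attachment is a larger change than the measured one. The expected step of a 1.4-fold higher number from compound 2 to compound 3 (0.13 log units; within the scatter) is therefore small, in either direction. Compound 3 is estimated at 1500 nM, within a range from 400 nM to 6000 nM.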

Compound 3, half-maximal inhibitory concentration: 600 nM
Beside the measured number, compound 3's estimate is 2.5-fold (0.40 log units) above it; the range from low to high includes it.
By their numbers in this assay, from the lowest: compounds 3, 1 and 2 (each within the scatter of the next).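

In this assay, (2,2,6,6-tetramethylpiperidin-4-yl)oxy in place of piperidin-1-yl on the carbonyl carbon gives a 1.8-fold lower number from compound 2 to compound 3 (0.26 log units; within the scatter), and in place of 4-(hydroxymethyl)piperidin-1-yl it gives a 1.8-fold lower number from compound 1 to compound 3 (0.26 log units; within the scatter). This position therefore accepts a far larger swap than the loss of a hydroxymethyl group, with a bigger group, an oxygen attachment and a hydrogen-bond donor, and all three compounds still lie within the scatter of each other. Nothing measured here accounts for this tolerance.

Compound 3 brings in the oxygen attachment and the tetramethyl substitution in one step, so the compounds shown cannot separate the two. Also open, on these data alone, is how a carboxylic acid or a longer chain on this carbonyl carbon would read, and whether any group here moves the number beyond the scatter.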